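The source may report more compounds than this note shows. Statements on the series, on what has been measured and on what is new or still open speak of the compounds shown alone.

Two compounds of a shared core have numbers here. Compound 1 `O=C(NO)c1ccc(CNC(=O)c2n[nH]cc2NC(=O)c2ccccc2Cl)cc1` gives 6170 nM in a functional assay on NCI-H460 cells (Homo sapiens) for inhibition, read by CCK-8 assay, with a stated time of 72 h; a lower number here means a stronger inhibitor, a higher number a weaker inhibitor. Compound 2 `Nc1ccccc1NC(=O)c1ccc(CNC(=O)c2n[nH]cc2NC(=O)c2ccccc2F)cc1` gives 9990 nM in this assay; of the two numbers shown it is the higher one, though its gap to compound 1 lies within the scatter, so the two cannot be told apart on these data.

Compound 3 `O=C(NO)c1ccc(CNC(=O)c2n[nH]cc2NC(=O)c2ccccc2F)cc1` has not been measured. It differs from compound 2 in one place: hydroxy in place of 2-aminophenyl on an amide-type nitrogen. Cut one bond further out, the change reads (2-aminophenyl)carbamoyl to hydroxycarbamoyl, so compound 3 carries the same hydroxycarbamoyl end that compound 1 carries.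

Within the data shown here, no step between two measured compounds shows what this change does. Among the measured compounds shown here, with compound 1 giving 6170 nM as the only guide, the step of a 1.8-fold lower number from compound 2 to compound 3 (0.26 log units; within the scatter) is expected to be small and, if anything, toward a lower number. Compound 3 is estimated to give 5500 nM in this assay, most likely between 2000 nM and 15000 nM.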

Compound 3, half-maximal inhibitory concentration: 23700 nM
Compound 3: middle estimate off by 4.3-fold (0.63 log units), on the low side; measured number outside the range, above it.
By their numbers in this assay, from the lowest: compounds 1 and 2 (each within the scatter of the next); then compound 3.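

In this assay, replacing 2-aminophenyl with hydroxy on the amide-type nitrogen does not lower the number, as compound 1 had suggested, but raises it modestly (a 2.4-fold higher number from compound 2 to compound 3 (0.38 log units; beyond the scatter)). The aromatic carbon carrying the halogen also matters: with the hydroxycarbamoyl end held constant, fluoro in place of chloro gives a modest rise (a 3.8-fold higher number from compound 1 to compound 3 (0.58 log units; beyond the scatter)). No measurement shown explains either step.

From the compounds shown here alone, each change is seen only once, so it remains open whether hydroxy in place of 2-aminophenyl would raise the number to the same extent in a compound carrying chloro rather than fluoro. Also open, going by these compounds, is how bromo or methyl on that aromatic carbon, or a carboxylic acid in place of the hydroxycarbamoyl end, would compare.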